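A few compounds are considered here, and "the series" means these few. Any claim that something is new, unique, unknown or untested is made for them only; others in the source may bear on it.

In a physicochemical assay for acid dissociation, compound 2 `CC(C)n1cc(-c2ccnc3[nH]c(C4CCN(CC(=O)N5CCCC5)CC4)cc23)ccc1=O` stands highest at 7.8 among the three measured compounds, above compound 1 `CNC(=O)CN1CCC(c2cc3c(-c4ccc(=O)n(C(C)C)c4)ccnc3[nH]2)CC1` at 6.9 and compound 3 `CC(C)n1cc(-c2ccnc3[nH]c(C4CCN(Cc5cccs5)CC4)cc23)ccc1=O` at 6.5 on the same scale.

Compound 4 `CC(C)n1cc(-c2ccnc3[nH]c(C4CCN(CC(=O)N(C)C)CC4)cc23)ccc1=O` is still unmeasured and carries one change from compound 2, dimethylamino in place of pyrrolidin-1-yl on a carbonyl carbon.

The closest measured step changes the group at that same place, with pyrrolidin-1-yl in place of methylamino, and shows a number 0.90 log units higher from compound 1 to compound 2 (beyond the scatter) as a modest move. The step that replaces the whole (pyrrolidin-1-yl)carbonyl with thiophen-2-yl shows a number 1.30 log units lower from compound 2 to compound 3 (beyond the scatter) as a large move, but compound 4 keeps the carbonyl, so this step bears on it less. For the measured compounds named here, no measured step exchanges pyrrolidin-1-yl for dimethylamino directly.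

In this assay no shift beyond the scatter is therefore expected, with at most a slight drop. The estimated change is a number 0.20 log units lower from compound 2 to compound 4 (within the scatter) and no more than that is expected. For compound 4 the estimate is 7.6 with an expected range of 7.1 to 8 at this stage.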

Compound 4, acid dissociation constant: 7.9
The estimate for compound 4 lay 0.30 log units below the measured number; the range from low to high includes it.
By their numbers in this assay, from the lowest: compound 3; then compound 1; then compounds 2 and 4 (each within the scatter of the next).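

In this assay, dimethylamino in place of pyrrolidin-1-yl on a carbonyl carbon gives a number 0.10 log units higher from compound 2 to compound 4 (within the scatter), so at this place the readout does not depend on the ring of pyrrolidin-1-yl. Methyl in place of hydrogen on an amide-type nitrogen gives a number 1.00 log units higher from compound 1 to compound 4 (beyond the scatter), so among the three amides, compounds 2 and 4, which lack the amide hydrogen, both stand apart from compound 1, which carries it. Dimethylcarbamoyl in place of thiophen-2-yl on a saturated chain carbon bound to an amine nitrogen in a ring gives a number 1.40 log units higher from compound 3 to compound 4 (beyond the scatter), a large step like the one already seen with the pyrrolidine amide. No available evidence accounts for these steps.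

Open, going by these compounds, is whether piperidin-1-yl, morpholin-4-yl or diethylamino on the same carbonyl carbon would read with compounds 2 and 4. Also open, on these data alone, is where a carboxylic acid or a longer chain in place of the amide would fall.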